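Swapping the unsaturated chain: compound 2 to compound 3

The source may hold more compounds than are shown below. What is called first, only, known or untested is meant among the compounds shown, and "the series" means these compounds.

In a functional assay on MDA-MB-231 cells (Homo sapiens) for antiproliferative activity, read by MTT assay (a higher number here means a weaker inhibitor, a lower number a stronger inhibitor), compound 2 `CCCC/C=C\CCCCCCCCCc1cc(=O)c2c(O)cc(O)cc2o1` gives 6790 nM, level with compound 1 `CCCCC/C=C\C/C=C\CCCCCCCc1cc(=O)c2c(O)cc(O)c(C)c2o1` at 6790 nM. Compound 3 `CCCCC/C=C\C/C=C\CCCCCCCc1cc(=O)c2c(O)cc(O)cc2o1` carries deca-1,4-dien-1-yl in place of oct-3-en-1-yl on a saturated chain carbon, seven bonds along the chain from an aromatic carbon. For the measured compounds named here, no measured step covers this change. Taking compound 2 at 6790 nM as the anchor, no step beyond the scatter is expected in this assay, in either direction. Compound 3 is estimated at 6500 nM, with an expected range of 2800 nM to 15000 nM.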

Compound 3, half-maximal inhibitory concentration: 6790 nM
Compound 3: the middle estimate sits 1.0-fold (0.02 log units) below what was measured; low and high end bracket the measured number.
By their numbers in this assay, from the lowest: compounds 1, 2 and 3 (each within the scatter of the next).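

In this assay, the chain length and the count of double bonds can differ at this position with no visible effect: deca-1,4-dien-1-yl in place of oct-3-en-1-yl gives no change at the digits printed from compound 2 to compound 3 (within the scatter) as its result. Hydrogen in place of methyl on an aromatic carbon reads the same way (no change at the digits printed from compound 1 to compound 3 (within the scatter)), so neither single change moves the value beyond the scatter. Nothing available bears on why the value holds across these changes.

Still open, as far as these compounds go, is whether a much shorter chain, or an amine or a carboxylic acid in place of the unsaturated chain, would give a step beyond the scatter. From the compounds shown here alone, whether a chlorine in place of that hydrogen on the aromatic carbon would do so is also open.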